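Fluoro for chloro on the benzyl ring of compound 2

A few compounds are considered here, and "the series" means these few. Any claim that something is new, unique, unknown or untested is made for them only; others in the source may bear on it.

The series shares one core and is compared in a functional assay on the whole organism for activation, with Mus musculus as the target; a higher number here means that more compound is needed for the effect, a lower number that less compound is needed. Among the measured compounds shown here, compound 1 `CCSc1nc(N)c2nc(O)n(Cc3ccccc3)c2n1` gives 0.1 mg/kg, and compound 3 `CCCCCNc1nc(N)c2nc(O)n(Cc3ccccc3)c2n1` gives 0.3 mg/kg; the one measured step, a 3.0-fold higher number from compound 1 to compound 3 (0.48 log units; beyond the scatter), is modest. Compound 2 `Nc1ncnc2c1nc(O)n2Cc1ccc(Cl)cc1` stands apart: in this assay compound 2 gives 30 mg/kg, the highest number of the three, well above compound 3 and further still above compound 1, both gaps beyond the scatter.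

Compound 4 `Nc1ncnc2c1nc(O)n2Cc1ccc(F)cc1` differs from compound 2 in one place: fluoro in place of chloro on an aromatic carbon. For the measured compounds named here, no measured step in the set concerns this exchange; the step from compound 1 to compound 3 alters a different part of the molecule and does not bear on it. With nothing to suggest a shift in either direction, the expected step for compound 4 is no change at the digits printed from compound 2 to compound 4 (within the scatter), that is, no change beyond the scatter. Compound 4 is therefore estimated at 30 mg/kg, within a range of 10 mg/kg to 100 mg/kg.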

Compound 4, minimum effective dose: 30 mg/kg
Estimate against measurement, compound 4: no gap at the digits printed, within the range that was stated.
By their numbers in this assay, from the lowest: compound 1; then compound 3; then compounds 2 and 4 (each within the scatter of the next).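

In this assay, among the compounds shown here, the change of chloro to fluoro gives no change at the digits printed from compound 2 to compound 4 (within the scatter), and this is the first step read on the benzyl ring, at the carbon para to a large group. The earlier step concerned only the exchange of ethylsulfanyl for pentylamino elsewhere on the shared core, so it said nothing about this place. Here, chlorine is not needed to keep the number where compound 2 puts it, as fluorine serves equally well, though the data offer nothing that explains this.

Still open, as far as these compounds go, is whether a group other than a halogen at this place, such as a methoxy group or a carboxylic acid, would move the number. Also open, from the compounds shown here alone, is whether fluoro and chloro would remain level on a core carrying ethylsulfanyl or pentylamino.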